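Cytotoxicity notes on a macrocyclic series before compound 4

The source may report more compounds than this note shows. Statements on the series, on what has been measured and on what is new or still open speak of the compounds shown alone.

Measured so far:
compound 1 `COc1ccc2c(O[C@H]3C[C@H]4C(=O)N(C)CCCC/C=C/[C@@H]5C[C@@]5(C(=O)NS(=O)(=O)C5(C)CC5)NC(=O)N4C3)cc(-c3nc(C(C)C)cs3)nc2c1` in an ADME assay on Huh-7 cells (Homo sapiens) for cytotoxicity, read by colorimetric assay; on this read-out lower numbers stand for higher toxicity in this test and higher numbers for lower toxicity in this test: 42700 nM
compound 2 `COc1ccc2c(O[C@H]3C[C@H]4C(=O)N(C)CCCC/C=C/[C@@H]5C[C@@]5(C(=O)NS(=O)(=O)C5(C)CC5)NC(=O)N4C3)cc(-c3nc(C(C)C)cs3)nc2c1Cl` in this assay: 48500 nM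
compound 3 `COc1ccc2c(O[C@H]3C[C@H]4C(=O)N(C)CCCC/C=C/[C@@H]5C[C@@]5(C(=O)NS(=O)(=O)C5(C)CC5)NC(=O)N4C3)cc(-c3nc(C(C)C)cs3)nc2c1Br` in this assay: 51200 nM

The three measured compounds share one core and differ only at a single aromatic carbon: hydrogen, chloro or bromo. The steps are a 1.1-fold higher number from compound 1 to compound 2 (0.06 log units; within the scatter), a 1.2-fold higher number from compound 1 to compound 3 (0.08 log units; within the scatter) and a 1.1-fold higher number from compound 2 to compound 3 (0.02 log units; within the scatter); all three lie within the scatter, so the halogen swaps read as flat. Compound 2 stands second highest of the three numbers, nearest to compound 3 and furthest from compound 1, both gaps within the scatter.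

Compound 4 `COc1ccc2c(O[C@H]3C[C@H]4C(=O)N(C)CCCC/C=C/[C@@H]5C[C@@]5(C(=O)NS(=O)(=O)C5(C)CC5)NC(=O)N4C3)cc(-n3cc(C(F)(F)F)cn3)nc2c1Cl` differs from compound 2 by 4-(trifluoromethyl)-1H-pyrazol-1-yl in place of 4-isopropyl-1,3-thiazol-2-yl on an aromatic carbon. For the measured compounds named here, no measured step concerns this exchange of the aryl substituent; the measured steps cover only the halogen position, and all were flat. There is thus no basis for expecting a shift beyond the scatter, and the uncertainty is wider than for the halogen steps. The expected step is a 1.1-fold lower number from compound 2 to compound 4 (0.03 log units; within the scatter). Compound 4 is therefore estimated at 45000 nM, with a range from 15000 nM to 130000 nM.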

Compound 4, half-maximal cytotoxic concentration: 21900 nM
Estimate against measurement, compound 4: 2.1-fold (0.31 log units) above; low and high end bracket the measured number.
By their numbers in this assay, from the lowest: compounds 4, 1, 2 and 3 (each within the scatter of the next, the first and the last beyond it).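

In this assay, for the compounds shown here, 4-(trifluoromethyl)-1H-pyrazol-1-yl in place of 4-isopropyl-1,3-thiazol-2-yl gives a 2.2-fold lower number from compound 2 to compound 4 (0.35 log units; beyond the scatter), a modest change and the first step to lie beyond the scatter. This aromatic carbon next to the ring nitrogen therefore affects the read-out, whereas the hydrogen, chloro and bromo exchanges at the halogen-bearing carbon read as flat. Nothing available accounts for this shift.

Ring and substituent change together in this exchange, so it remains open whether the step follows the trifluoromethyl group or the ring; a 4-isopropyl-1H-pyrazol-1-yl or a 4-(trifluoromethyl)-1,3-thiazol-2-yl group would separate the two. On these data alone, it is also open whether the same step holds with hydrogen or bromo in place of chloro on the shared core.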